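Changing the benzyl substitution on compound 1

The source may report more compounds than this note shows. Statements on the series, on what has been measured and on what is new or still open speak of the compounds shown alone.

The measured compounds, all in a functional assay on K562 cells (Homo sapiens) for antiproliferative activity, with a stated time of 72 h; a higher number here means a weaker inhibitor, a lower number a stronger inhibitor:
compound 1 `OC[C@H]1O[C@@H](n2cnc3c(NCc4ccccc4Cl)ncnc32)[C@H](O)[C@@H]1O` gives 64000 nM.
compound 2 `Cc1ccc(CNc2ncnc3c2ncn3[C@@H]2O[C@H](CO)[C@@H](O)[C@H]2O)cc1` gives only a limit of the assay, > 166000 nM.
compound 3 `COc1cccc(CNc2ncnc3c2ncn3[C@@H]2O[C@H](CO)[C@@H](O)[C@H]2O)c1` gives only a limit of the assay, > 166000 nM.

Among the compounds with values here, compound 1 is the only compound with an actual number; the other two values are limits (the limit of > 166000 nM in this assay, at which 2 of the 3 values shown sit). Compound 4 `OC[C@H]1O[C@@H](n2cnc3c(NCc4ccc(F)c(Cl)c4)ncnc32)[C@H](O)[C@@H]1O` is not yet measured. It differs from compound 1 in one place: 3-chloro-4-fluorophenyl in place of 2-chlorophenyl on a saturated chain carbon bound to a nitrogen on an aromatic ring.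

Within the data shown here, two measured steps bear on this change. Both replace the 2-chlorophenyl of compound 1 with a differently substituted phenyl on the same saturated chain carbon bound to a nitrogen on an aromatic ring: an at least 2.5-fold higher number from compound 1 to compound 2 (0.41 log units; beyond the scatter) and an at least 2.5-fold higher number from compound 1 to compound 3 (0.41 log units; beyond the scatter). From the compounds shown here alone, both reach the limit, so their true size is unknown, but each is at least modest and in the weakening direction. The step from compound 2 to compound 3 cannot be read, since both are limits.

Compound 4 keeps a chlorine but adds a fluorine and shifts the substitution pattern, and the two known moves away from 2-chlorophenyl both weakened activity. Compound 4 is therefore expected to be weaker than compound 1, with an estimated step of a 2.3-fold higher number from compound 1 to compound 4 (0.37 log units; beyond the scatter). The estimate for compound 4 in this assay is 150000 nM, between 50000 nM and 400000 nM, with a real chance that only a limit is reported.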

Compound 4, half-maximal inhibitory concentration: 5500 nM
Compound 4: middle estimate off by 27-fold (1.44 log units), on the high side; the whole stated range lies above it.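

In this assay, this place on the saturated chain carbon bound to a nitrogen on an aromatic ring can strengthen activity as well as weaken it: the earlier moves away from 2-chlorophenyl pointed only toward weaker compounds, whereas 3-chloro-4-fluorophenyl gives a 12-fold lower number from compound 1 to compound 4 (1.07 log units; beyond the scatter). The gap is wider still against the other two aryl groups, with an at least 30-fold lower number from compound 3 to compound 4 (1.47 log units; beyond the scatter) and an at least 30-fold lower number from compound 2 to compound 4 (1.47 log units; beyond the scatter), so the substitution on this phenyl ring decides much of the activity seen across these four compounds. Those two wider gaps are only minimum sizes, since compound 2 and compound 3 each rest on a limit of the assay: the limit of > 166000 nM in this assay, at which 2 of the 4 values shown sit.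

Compound 4 differs from compound 1 both in where the chlorine sits and in the added fluorine, and the compounds shown cannot separate these two changes. Also open, from the compounds shown here alone, is how a plain 3-chlorophenyl, a plain 4-fluorophenyl or a 3-bromo-4-fluorophenyl group would read at this place, which would show how much each halogen contributes to the gain.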